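From iodophenyl to naphthyl on the amide carbonyl

The source may hold more compounds than are shown below. What is called first, only, known or untested is meant among the compounds shown, and "the series" means these compounds.

Compound 2 `Cc1ccc(C)c(COc2cc(NC(=O)c3ccc(I)cc3)ccc2N(C)S(=O)(=O)C(F)(F)F)c1` is the weaker of the two measured compounds in a functional assay on SK-BR-3 cells (Homo sapiens) for antiproliferative activity, read by MTT assay, with a stated time of 48 h (a higher number here means a weaker inhibitor, a lower number a stronger inhibitor), where compound 2 gives 13500 nM. Going by the values given here, its nearest neighbour is compound 1 `COc1ccc(C(=O)Nc2ccc(N(C)S(=O)(=O)C(F)(F)F)c(OCc3cc(C)ccc3C)c2)cc1`, which in this assay gives 5320 nM; the only measured step, a 2.5-fold higher number from compound 1 to compound 2 (0.40 log units; beyond the scatter), comes from iodo in place of methoxy on an aromatic carbon. Compound 3 `Cc1ccc(C)c(COc2cc(NC(=O)c3ccc4ccccc4c3)ccc2N(C)S(=O)(=O)C(F)(F)F)c1` differs from compound 2 by naphthalen-2-yl in place of 4-iodophenyl on a carbonyl carbon. Among the compounds with values here, no measured step bears directly on this exchange; the single step that exists, methoxy to iodo, was modest, and it shows that a change of the group on the carbonyl carbon has so far moved the number only moderately. A step of similar or smaller size is therefore expected for compound 3, in either direction, and quite possibly not beyond the scatter. On that basis compound 3 is expected to give 10000 nM in this assay, within 4000 nM to 25000 nM, which corresponds to an expected step of a 1.4-fold lower number from compound 2 to compound 3 (0.13 log units; within the scatter).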

Compound 3, half-maximal inhibitory concentration: 41400 nM
The estimate for compound 3 lay 4.1-fold (0.62 log units) below the measured number; measured number above the stated range.
By their numbers in this assay, from the lowest: compound 1; then compound 2; then compound 3.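

The exchange of 4-iodophenyl for naphthalen-2-yl on the carbonyl carbon gave a 3.1-fold higher number from compound 2 to compound 3 (0.49 log units; beyond the scatter) in this assay and so showed that a second aromatic ring at this position did not restore activity. Compared with the 4-methoxyphenyl group, naphthalen-2-yl gave a 7.8-fold higher number from compound 1 to compound 3 (0.89 log units; beyond the scatter) and this is a wider span than the first step had revealed at this position. Among the three groups shown on this carbonyl carbon, 4-methoxyphenyl therefore gives the lowest number, and neither replacement improves on it.

No evidence is available to explain these differences. On these data alone, it remains open whether a saturated ring such as cyclohexyl on the carbonyl carbon, or an amine or a carboxylic acid on its phenyl ring, would bring the number below that of compound 1.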